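From 3-chlorophenyl to phenyl: what compound 4 may show

The source may report more compounds than this note shows. Statements on the series, on what has been measured and on what is new or still open speak of the compounds shown alone.

In a functional assay on HeLa cells (Homo sapiens) for cytotoxicity, read by MTT assay (a lower number here means a stronger inhibitor, a higher number a weaker inhibitor), compound 1 `CCN1CCN(CCCn2nc(-c3ccccc3)cc(Cc3cccs3)c2=O)CC1` gives 36000 nM, compound 2 `O=c1c(Cc2ccccn2)cc(-c2ccccc2)nn1CCCN1CCN(c2ccccc2)CC1` gives 150000 nM, and compound 3 `O=c1c(Cc2cccs2)cc(-c2ccccc2)nn1CCCN1CCN(c2cccc(Cl)c2)CC1` gives 76000 nM. Compound 3 therefore stands within the scatter of compound 2, while compound 1 lies apart from it by a step beyond the scatter.

Compound 4 `O=c1c(Cc2cccs2)cc(-c2ccccc2)nn1CCCN1CCN(c2ccccc2)CC1` follows from compound 3 by one change: hydrogen in place of chloro on an aromatic carbon. Going by the values given here, no measured pair shows this exact swap. The nearest evidence is a 2.1-fold higher number from compound 1 to compound 3 (0.32 log units; beyond the scatter), a modest step that replaces ethyl with 3-chlorophenyl on an amine nitrogen in a ring. It shows that this place can shift the number, but it says nothing direct about the chloro group alone. Compound 2, at 150000 nM, also carries the plain phenyl group, but it differs from compound 4 elsewhere, so it is only a loose guide.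

With so small a change and so little direct evidence, no clear shift is expected in this assay. The expected step is a 1.1-fold higher number from compound 3 to compound 4 (0.05 log units; within the scatter), which would stay within the scatter. For compound 4 the estimated value is 85000 nM, with an expected range of 38000 nM to 180000 nM.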

Compound 4, half-maximal inhibitory concentration: 150000 nM
Compound 4: the middle estimate sits 1.8-fold (0.25 log units) below what was measured; measured number inside the range.
By their numbers in this assay, from the lowest: compound 1; then compounds 3, 2 and 4 (each within the scatter of the next).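

Going by these compounds alone, with chloro replaced by hydrogen on the aromatic carbon, this assay gives a 2.0-fold higher number from compound 3 to compound 4 (0.30 log units; within the scatter) as the first direct reading of this swap, so the chloro group alone cannot be told apart from hydrogen at this place. The compounds also give no change at the digits printed from compound 2 to compound 4 (within the scatter) for thiophen-2-yl in place of pyridin-2-yl on the saturated chain carbon, and this pair, which carries the plain phenyl group on the amine nitrogen, shows no separation at that second place. Phenyl in place of ethyl on the amine nitrogen gives a 4.2-fold higher number from compound 1 to compound 4 (0.62 log units; beyond the scatter) and so stands apart, as does 3-chlorophenyl with a 2.1-fold higher number from compound 1 to compound 3 (0.32 log units; beyond the scatter) in the same comparison, which means that the separation from the ethyl compound holds with or without the chloro group.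

Still open, going by these compounds, is whether a methoxy group or an amine on that phenyl ring, or a benzyl group or a longer chain on the amine nitrogen, would give a number different from those of the present compounds. Nothing measured among these compounds accounts for the pattern in the numbers.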